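From thiophen-2-yl to 2-fluorophenyl in one series

The source may report more compounds than this note shows. Statements on the series, on what has been measured and on what is new or still open speak of the compounds shown alone.

- compound 1 (`O=C1N=C(N2CCC[C@H]2C(=O)Nc2ccc3ncnc(Nc4cccc(Cl)c4)c3c2)S/C1=C/c1cccs1`), value (6100 nM)
- compound 2 (`O=C1N=C(N2CCC[C@H]2C(=O)Nc2ccc3ncnc(Nc4cccc(Cl)c4)c3c2)S/C1=C/c1cccc(Br)c1`), value (> 50000 nM), a limit

Within the data shown here, in a functional assay on A549 cells (Homo sapiens) for antiproliferative activity, read by MTT assay (on this read-out lower numbers stand for stronger inhibition and higher numbers for weaker inhibition), compound 1 gives 6100 nM and holds the only exact number so far. Compound 2 gives > 50000 nM as a limit. Compound 3 (`O=C1N=C(N2CCC[C@H]2C(=O)Nc2ccc3ncnc(Nc4cccc(Cl)c4)c3c2)S/C1=C/c1ccccc1F`) departs from compound 1 at one place (2-fluorophenyl in place of thiophen-2-yl on a double-bonded chain carbon bound to a double-bonded ring carbon). Among the measured compounds shown here, the only measured step at that place, an at least 8.1-fold higher number from compound 1 to compound 2 (0.91 log units; beyond the scatter) with 3-bromophenyl entering, points to a higher number, though it ends at a limit. A step in the same direction is expected, and its size is estimated as a 2.0-fold higher number from compound 1 to compound 3 (0.29 log units; within the scatter) in this assay with wide uncertainty. Compound 3 is expected at 12000 nM within an estimated range from 3000 nM to 50000 nM on this read-out.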

Compound 3, half-maximal inhibitory concentration: 34500 nM
For compound 3 the middle estimate is 2.9-fold (0.46 log units) below the measured one, and the stated range covers the measured number.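

Replacing thiophen-2-yl with 2-fluorophenyl gives a 5.7-fold higher number from compound 1 to compound 3 (0.75 log units; beyond the scatter) in this assay, so the rise at this position now has a measured size and no longer rests on a limit alone. Both phenyl groups shown, 2-fluorophenyl and 3-bromophenyl, give higher numbers than thiophen-2-yl. Between these two, the result is an at least 1.4-fold lower number from compound 2 to compound 3 (0.16 log units; that floor lies within the scatter), and no order can be claimed, as compound 2 holds only a limit: the limit of > 50000 nM in this assay, at which 1 of the 3 values shown sits.

The compounds shown leave open whether the halogen or the phenyl ring itself accounts for the rise. As far as these compounds go, how unsubstituted phenyl or furan-2-yl would behave at this place also remains open.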